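Aminophenyl regioisomers on the shared core

The compounds below may be only part of what the source reports. "The series", "measured", "known", "first", "only" and "open" are said of these compounds alone.

Measured: compound 1 `CCCS(=O)(=O)Nc1ccc(F)c(C(=O)c2n[nH]c3ncc(-c4cccc(F)c4)cc23)c1F` gives 8.2% in an assay for binding affinity to dual specificity mitogen-activated protein kinase kinase 4 (Homo sapiens), read by KINOMEscan, tested at 100 nM; on this read-out higher numbers stand for a weaker effect at the one concentration tested and lower numbers for a stronger effect; compound 2 `CCCS(=O)(=O)Nc1ccc(F)c(C(=O)c2n[nH]c3ncc(-c4ccccc4N)cc23)c1F` gives 23% in this assay.

Among the compounds with values here, compound 2 stands highest of the two numbers; the only measured step, a number 14.8 percentage points higher from compound 1 to compound 2 (beyond the scatter), concerns a different change and bears on the present one only loosely. Compound 3 `CCCS(=O)(=O)Nc1ccc(F)c(C(=O)c2n[nH]c3ncc(-c4ccc(N)cc4)cc23)c1F` differs from compound 2 by 4-aminophenyl in place of 2-aminophenyl on an aromatic carbon. Within the data shown here, with no measured step touching this change, no move beyond the scatter is expected in this assay. For compound 3 the estimate is 22% (range 5% to 50%), a step of a number 1 percentage points lower from compound 2 to compound 3 (within the scatter) that is expected to stay within the scatter.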

Compound 3, a percentage reported as activity, at one concentration (the size of the read-out at that concentration, not a potency): 0.1%
Estimate against measurement, compound 3: 21.9 percentage points above; measured number below the stated range.
By their numbers in this assay, from the lowest: compounds 3 and 1 (each within the scatter of the next); then compound 2.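

At this aromatic carbon of the shared core, the placement of the amine on the phenyl ring matters in this assay: 4-aminophenyl in place of 2-aminophenyl gives a number 22.9 percentage points lower from compound 2 to compound 3 (beyond the scatter), with the same atoms joined differently. 4-Aminophenyl in place of 3-fluorophenyl gives a number 8.1 percentage points lower from compound 1 to compound 3 (within the scatter), so compound 3 and compound 1 cannot be told apart on this read-out. Nothing available accounts for the gap between the two aminophenyl isomers.

As far as these compounds go, the remaining aminophenyl regioisomer stays open. So does the outcome with a hydroxyl group or a carboxylic acid in place of the amine on the phenyl ring.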